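The source may hold more compounds than are shown below. What is called first, only, known or untested is meant among the compounds shown, and "the series" means these compounds.

Working notes on the series. In a functional assay on BT-474 cells (Homo sapiens) for inhibition, read by CellTiter-Glo, with a stated time of 72 h (on this read-out higher numbers stand for weaker inhibition and lower numbers for stronger inhibition), compound 1 (`C=C(F)C(=O)Nc1cc2c(Nc3ccc(Oc4cc5nncn5cn4)c(C)c3)ncnc2cc1OCC`) gives 3.88 nM as its half-maximal inhibitory concentration. Compound 2 (`Cc1cc(Nc2ncnc3cc(O)c(NC(=O)/C=C/[C@H]4CCCN4C)cc23)ccc1Oc1cc2nccn2cn1`) gives 5.59 nM in the same read-out, and the two numbers lie within the scatter of each other. Compound 2 therefore stands level with compound 1 on the numbers available, and neither can be ranked over the other.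

Compound 3 (`Cc1cc(Nc2ncnc3cc(O)c(NC(=O)/C=C/[C@H]4CCCN4C)cc23)ccc1Oc1ccc2nccn2c1`) has not yet been measured in this assay and differs from compound 2 in one place (a group of 9 heavy atoms (7 carbon, 2 nitrogen; one five-membered aromatic ring with 2 hetero atoms, one six-membered aromatic ring with 1 hetero atom) in place of a group of 9 heavy atoms (6 carbon, 3 nitrogen; one five-membered aromatic ring with 2 hetero atoms, one six-membered aromatic ring with 2 hetero atoms), on an oxygen on an aromatic ring), on an oxygen on an aromatic ring. The group that enters keeps one five-membered aromatic ring with 2 hetero atoms and carries one six-membered aromatic ring with 1 hetero atom in place of one with 2 hetero atoms.

For the measured compounds named here, no measured pair in this set differs in one place, so the data hold no direct precedent for this exchange. Going by the values given here, the only anchor is compound 2 at 5.59 nM in this read-out, and no change beyond the scatter is expected. The expected move is a 1.3-fold higher number from compound 2 to compound 3 (0.10 log units; within the scatter) and no more than that. For compound 3 the estimated value is 7 nM with 2.5 nM and 20 nM as the ends of its expected range.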

Compound 3, half-maximal inhibitory concentration: 5.22 nM
Estimate against measurement, compound 3: 1.3-fold (0.13 log units) above; the measured number falls inside the stated range.
By their numbers in this assay, from the lowest: compounds 1, 3 and 2 (each within the scatter of the next).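

For the compounds shown here, the exchange on an oxygen on an aromatic ring gives, in this assay, a 1.1-fold lower number from compound 2 to compound 3 (0.03 log units; within the scatter), the first step that can be read in one place. At this position, the group with one six-membered aromatic ring with 1 hetero atom and the group with one six-membered aromatic ring with 2 hetero atoms cannot be told apart on this read-out, although the group that leaves counts 3 hydrogen-bond acceptors and the one that enters counts 2. Nothing in the data available speaks to the reason for this outcome.

This single step says nothing about how far the position tolerates groups of another kind, such as a plain phenyl ring or a small methyl group on the same oxygen. Also open, on these data alone, is whether the same exchange would stay within the scatter on the core of compound 1, which carries an ethoxy group and a different amide.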